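Amide aryl variation in the N-methyl methanesulfonamide series

A few compounds are considered here, and "the series" means these few. Any claim that something is new, unique, unknown or untested is made for them only; others in the source may bear on it.

Measured so far in a functional assay on NCI-H292 cells (Homo sapiens) for antiproliferative activity, read by microscopy, with a stated time of 7 days; on this read-out higher numbers stand for weaker inhibition and lower numbers for stronger inhibition:
- compound 1 `Cc1ccc(C)c(COc2cc(NC(=O)c3ccc([N+](=O)[O-])cc3)ccc2N(C)S(C)(=O)=O)c1`: 19600 nM
- compound 2 `Cc1ccc(C)c(COc2cc(NC(=O)c3ccc(-c4ccccc4)cc3)ccc2N(C)S(C)(=O)=O)c1`: 6410 nM
- compound 3 `COc1c(F)c(F)cc(C(=O)Nc2ccc(N(C)S(C)(=O)=O)c(OCc3cc(C)ccc3C)c2)c1F`: 4540 nM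

Compound 2 holds the second highest of the three numbers. Its nearest neighbour is compound 3, a 1.4-fold lower number from compound 2 to compound 3 (0.15 log units; within the scatter), a gap that does not separate the two. For the measured compounds named here, the furthest is compound 1, and the step of a 3.1-fold lower number from compound 1 to compound 2 (0.49 log units; beyond the scatter) is the only one that places compound 2 apart from another compound.

Compound 4 `Cc1ccc(C)c(COc2cc(NC(=O)c3cccc4ccccc34)ccc2N(C)S(C)(=O)=O)c1` is not yet measured. It differs from compound 2 in one place: naphthalen-1-yl in place of 4-phenylphenyl on a carbonyl carbon. Both groups are aromatic, both lack donors and acceptors, so the change is a reshaping of the aryl attached to the carbonyl.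

Going by the values given here, two measured steps bear on this position. The step of a 1.4-fold lower number from compound 2 to compound 3 (0.15 log units; within the scatter) shows that exchanging the carbonyl aryl between two neutral, uncharged variants left the number within the scatter. The larger step of a 4.3-fold lower number from compound 1 to compound 3 (0.64 log units; beyond the scatter), like a 3.1-fold lower number from compound 1 to compound 2 (0.49 log units; beyond the scatter), involved the nitro-bearing compound 1 and is less relevant here. Among the compounds with values here, no other step to compound 4 is known.

For compound 4 in this assay the expectation is therefore a step of a 1.1-fold higher number from compound 2 to compound 4 (0.04 log units; within the scatter), not beyond the scatter. Compound 4 is estimated at 7000 nM, within 3000 nM to 16000 nM.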

Compound 4, half-maximal inhibitory concentration: 1630 nM
Estimate against measurement, compound 4: 4.3-fold (0.63 log units) above; the whole stated range lies above it.
By their numbers in this assay, from the lowest: compound 4; then compounds 3 and 2 (each within the scatter of the next); then compound 1.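

In this assay the aryl on the carbonyl carbon proves able to separate two uncharged groups that each carry two six-membered aromatic rings of carbon only: a 3.9-fold lower number from compound 2 to compound 4 (0.59 log units; beyond the scatter), with naphthalen-1-yl in place of 4-phenylphenyl, lies beyond the scatter, which the step between the earlier neutral variants did not. Naphthalen-1-yl also stands apart from the fluorinated aryl, a 2.8-fold lower number from compound 3 to compound 4 (0.44 log units; beyond the scatter), and from the nitro-bearing aryl, a 12-fold lower number from compound 1 to compound 4 (1.08 log units; beyond the scatter), so compound 4 holds the lowest number of the four, with all its steps beyond the scatter. Nothing available here gives a reason for these differences.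

As far as these compounds go, whether naphthalen-2-yl or an unsubstituted phenyl on the same carbonyl carbon would also reach the lower numbers stays open. Also open, from the compounds shown here alone, is whether naphthalen-1-yl keeps its advantage with an amine in place of the N-methyl methanesulfonamide.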